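The source may report more compounds than this note shows. Statements on the series, on what has been measured and on what is new or still open speak of the compounds shown alone.

- Compound 1 `CCCC(=O)OCSc1ccccc1C(=O)NCC(N)=O`: > 100 uM (a limit)
- Compound 2 `CCCC(=O)OCSc1ccccc1C(=O)NCCCCCNC(C)=O`: 9.2 uM
- Compound 3 `CCCC(=O)OCSc1ccccc1C(=O)N[C@@H]1CCC[C@@H]1C(N)=O`: 90 uM

All three were tested in an ADME assay on CEM-SS cells (Homo sapiens) for cytotoxicity, read by XTT assay, with a stated time of 6 days (on this read-out higher numbers stand for lower toxicity in this test and lower numbers for higher toxicity in this test), and share one core. The entry for compound 1 is a limit of the assay and not a number. Of the two actual numbers, compound 3 at 90 uM is the higher, and compound 2 at 9.2 uM is the lower.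

Compound 4 `CCCC(=O)OCSc1ccccc1C(=O)NCC(=O)OC` is still unmeasured. Going to it from compound 3 places (methoxycarbonyl)methyl in place of 2-carbamoylcyclopentyl on an amide-type nitrogen (the counted difference: (methoxycarbonyl)methyl in place of 2-carbamoylcyclopentyl on an amide-type nitrogen).

For the measured compounds named here, two measured steps bear on this. The nearer one is an at least 1.1-fold lower number from compound 1 to compound 3 (0.04 log units; that floor lies within the scatter) and concerns the same position, with carbamoylmethyl as the group that leaves, so this exchange has shown no change beyond the scatter. The other, an at least 10-fold lower number from compound 1 to compound 2 (1.03 log units; beyond the scatter), is large, but it brings in 4-acetamidobutyl, which compound 4 does not carry, and so it counts for little here.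

No step beyond the scatter is therefore expected in this assay, and the expected change is small (estimated: a 1.3-fold lower number from compound 3 to compound 4 (0.11 log units; within the scatter)). For compound 4 the estimated value is 70 uM, with an expected range of 25 uM to 130 uM (a report of a limit alone is also possible).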

Compound 4, half-maximal toxic concentration: 27.3 uM
Beside the measured number, compound 4's estimate is 2.6-fold (0.41 log units) above it; measured number inside the range.
By their numbers in this assay, from the lowest: compound 2; then compound 4; then compound 3. At a limit, above all of these: compound 1.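

In this assay, the place on the amide-type nitrogen now shows a change beyond the scatter: (methoxycarbonyl)methyl in place of 2-carbamoylcyclopentyl gives a 3.3-fold lower number from compound 3 to compound 4 (0.52 log units; beyond the scatter), whereas the earlier exchange there, of carbamoylmethyl for 2-carbamoylcyclopentyl, showed none. Exchanging only methoxy for amino on a carbonyl carbon gives an at least 3.6-fold lower number from compound 1 to compound 4 (0.56 log units; beyond the scatter), so a change of this one group already moves the number beyond the scatter, while the other comparison, a 3.0-fold higher number from compound 2 to compound 4 (0.47 log units; beyond the scatter), shows that methoxycarbonyl does not bring the number down as far as 4-acetamidobutyl does. The entry for compound 1 is a limit, and the step from it is therefore only a floor: the limit of > 100 uM in this assay, at which 1 of the 4 values shown sits.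

The compounds shown leave open whether the lower number belongs to the methoxy group in particular, which a carboxylic acid or an ethyl ester on the same carbonyl carbon would help to settle. They also leave open how a longer chain between the amide-type nitrogen and the methoxycarbonyl group, or a methoxycarbonyl group on the cyclopentyl ring in place of carbamoyl, would read in this assay.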